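The compounds below may be only part of what the source reports. "The series", "measured", "known", "first", "only" and "open" are said of these compounds alone.

Working notes on the series. Compound 1 `O=C(NC/C=C\Cn1ccc(=O)[nH]c1=O)c1ccccc1` in a functional assay on HeLa cells (Homo sapiens) for cytotoxicity, read by MTT assay, with a stated time of 72 h (on this read-out higher numbers stand for weaker inhibition and lower numbers for stronger inhibition), gives 4900 nM. Compound 2 `O=C(NC/C=C\Cn1cc(F)c(=O)[nH]c1=O)c1ccccc1` differs from it by fluoro in place of hydrogen on an aromatic carbon. In this assay compound 2 reaches only > 100000 nM, which is a limit of the assay and not a number (the limit of > 100000 nM in this assay, at which 1 of the 2 values shown sits). The step of an at least 20-fold higher number from compound 1 to compound 2 (1.30 log units; beyond the scatter) is therefore a lower bound on the loss. Compound 2 thus stands at the weak end of the two values shown and has no measured number of its own.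

Compound 3 `Cc1cn(C/C=C\CNC(=O)c2ccccc2)c(=O)[nH]c1=O` carries methyl in place of fluoro on an aromatic carbon. For the measured compounds named here, no measured step changes fluoro to methyl, so the only bearing comes from the hydrogen-to-fluoro step an at least 20-fold higher number from compound 1 to compound 2 (1.30 log units; beyond the scatter), which was large. Compound 3 removes that fluoro and puts a methyl of the same heavy-atom count on the same aromatic carbon, and its value in this assay is expected to fall somewhere between the two measured values, with wide uncertainty and a real chance that only a limit is reported. Compound 3 is estimated at 40000 nM, within 6000 nM to 150000 nM, meaning an at least 2.5-fold lower number from compound 2 to compound 3 (0.39 log units; beyond the scatter).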

Compound 3, half-maximal inhibitory concentration: > 100000 nM
Compound 3: no number, only a limit (the forecaster's own chance of this, stated with the estimate: 40%); middle value at least 2.5-fold (0.39 log units) from the limit.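

Methyl in place of hydrogen on this aromatic carbon, para to a group of 1 heavy atom, gives in this assay an at least 20-fold higher number from compound 1 to compound 3 (1.30 log units; beyond the scatter), and this too is only a lower bound on the loss. The large loss seen on going to fluoro is therefore not particular to fluoro: of the compounds shown, only compound 1, with hydrogen at this position, has a measured number, and both one-heavy-atom replacements leave the read-out at the limit of this assay. The step between the fluoro and methyl compounds cannot be read, so the two groups cannot be ranked against each other at this position: the limit of > 100000 nM in this assay, at which 2 of the 3 values shown sit.

Going by these compounds, how far compound 2 and compound 3 really lie from compound 1 stays open, as does whether any replacement for hydrogen at this position, such as an amine, a hydroxyl or chlorine, keeps a measurable value in this assay. Also open, on these data alone, is whether the loss holds on other versions of the core, for example with a carboxylic acid on the benzamide end or a longer chain in place of the linker.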